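The source may report more compounds than this note shows. Statements on the series, on what has been measured and on what is new or still open speak of the compounds shown alone.

Measured compounds:
compound 1 `CC1CCN(c2c(S(=O)(=O)c3cccc(Cl)c3)cnc3cc(Cl)ccc23)CC1`, 92%
compound 2 `COc1ccc2ncc(S(=O)(=O)c3ccc(OC)c(Cl)c3)c(N3CCC(C)CC3)c2c1`, 21%
compound 3 `CC1CCN(c2c(S(=O)(=O)c3cccc(F)c3)cnc3ccc(Cl)cc23)CC1`, 58%

In an assay on isolated protein for displacement of a labelled ligand from metabotropic glutamate receptor 5 (Homo sapiens), with a stated time of 60 min, tested at 1 uM (on this read-out lower numbers stand for less inhibition and higher numbers for more inhibition at the one concentration tested (going by the name of the read-out)), compound 1 gives the highest number of the three. Compound 3 comes nearest, yet its number lies lower by more than the scatter allows, and compound 2 lies furthest below it, again well beyond the scatter. Compound 4 `CC1CCN(c2c(S(=O)(=O)c3ccc(Cl)c(Cl)c3)cnc3cc(Cl)ccc23)CC1` has not yet been measured. It differs from compound 1 in one place: chloro in place of hydrogen on an aromatic carbon, so that the 3-chlorophenyl of compound 1 becomes a 3,4-dichlorophenyl. Among the measured compounds shown here, no measured pair shows the effect of this change. Because compound 1 already gives 92%, little room remains upward, and the expected step of a number 4 percentage points lower from compound 1 to compound 4 (within the scatter) in this assay is none beyond the scatter. Compound 4 is estimated at 88%, within 70% to 99%.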

Compound 4, a percentage reported as inhibition, at one concentration (the size of the read-out at that concentration, not a potency): 89%
The estimate for compound 4 lay 1 percentage points below the measured number, and the stated range covers the measured number.
By their numbers in this assay, from the lowest: compound 2; then compound 3; then compounds 4 and 1 (each within the scatter of the next).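

In this assay, chloro in place of hydrogen on an aromatic carbon, turning the 3-chlorophenyl into a 3,4-dichlorophenyl, gives a number 3 percentage points lower from compound 1 to compound 4 (within the scatter). Among the compounds shown here, this carbon, ortho to a chloro group and para to a large group, therefore accepts a second chloro without a change in the read-out beyond the scatter, something no earlier pair could show. Nothing here offers an explanation for this outcome.

From the compounds shown here alone, whether an amine or a carboxylic acid would be accepted on this same carbon remains open. A reading at one concentration also leaves open whether compound 1 and compound 4 differ in potency.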